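Aryl five-membered heterocycle exchange in the shared-core series

The source may hold more compounds than are shown below. What is called first, only, known or untested is meant among the compounds shown, and "the series" means these compounds.

Values in an in vitro functional assay on cells (Fibroblast) for agonist activity at Alpha-1A adrenergic receptor (Homo sapiens) (on this read-out lower numbers stand for an effect already at smaller amounts and higher numbers for an effect only at larger amounts of compound), so far:
compound 1 `Cc1nc(-c2ccccc2NCC2=NCCN2)n(C)n1`: 1000 nM
compound 2 `CCn1cccc1-c1ccccc1NCC1=NCCN1`: 2.51 nM
compound 3 `c1ccc(-c2nc[nH]n2)c(NCC2=NCCN2)c1`: 0.794 nM

Compound 3 gives the lowest number of the three. Compound 2 stands a step beyond the scatter above it, and compound 1 lies far above both. Within the data shown here, no pair of measured compounds differs in only one place, so the ring comparisons rest on whole-molecule contrasts.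

Compound 4 `Cn1cc(-c2ccccc2NCC2=NCCN2)cn1` is not yet measured. It differs from compound 3 by 1-methyl-1H-pyrazol-4-yl in place of 1H-1,2,4-triazol-3-yl on an aromatic carbon. The entering ring carries no hydrogen-bond donor, as is the case for the ring of compound 2.

Expectation: a modest rise in this assay, beyond the scatter, of size a 3.1-fold higher number from compound 3 to compound 4 (0.50 log units; beyond the scatter), because compound 2 gives 2.51 nM with a comparable donor-free ring. Compound 4 is estimated at 2.5 nM, range 0.6 nM to 10 nM.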

Compound 4, half-maximal effective concentration: 398 nM
Compound 4: the middle estimate sits 160-fold (2.20 log units) below what was measured, and the stated range ends below it.
By their numbers in this assay, from the lowest: compound 3; then compound 2; then compound 4; then compound 1.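

In this assay, among these compounds, 1-methyl-1H-pyrazol-4-yl in place of 1H-1,2,4-triazol-3-yl on an aromatic carbon gives a 500-fold higher number from compound 3 to compound 4 (2.70 log units; beyond the scatter), the first single-place step, so the number depends strongly on which five-membered ring stands at this position. The exchange alters the ring's hetero atoms, its hydrogen-bond donor count and its methyl together, and these changes cannot be separated here. No available measurement explains the step.

Open, going by these compounds, is whether the unmethylated 1H-pyrazol-4-yl ring would stay near compound 3 or near compound 4. Also open, on these data alone, is how an amine on the triazole ring would read.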